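Alkyl swaps on the aryl ring leave inhibition flat

A few compounds are considered here, and "the series" means these few. Any claim that something is new, unique, unknown or untested is made for them only; others in the source may bear on it.

compound 1 `CCCCc1ccc(-c2c(C)[nH]c(=O)n2C)cc1` gives 10700 nM
compound 2 `Cc1[nH]c(=O)n(C)c1-c1ccc(CC(C)C)cc1` gives 7800 nM
compound 3 `Cc1[nH]c(=O)n(C)c1-c1ccc(C(C)(C)C)cc1` gives 8400 nM

In a functional assay on brain (Rattus norvegicus, strain Wistar) for inhibition (on this read-out lower numbers stand for stronger inhibition and higher numbers for weaker inhibition), compound 3 gives 8400 nM, and it stands within the scatter of both other measured compounds. The change now in question leads to compound 4 `Cc1[nH]c(=O)n(C)c1-c1ccc(C2CCCCC2)cc1` and is cyclohexyl in place of tert-butyl on an aromatic carbon. Going by the values given here, three measured steps bear on it. Tert-butyl in place of butyl gave a 1.3-fold lower number from compound 1 to compound 3 (0.11 log units; within the scatter), tert-butyl in place of isobutyl gave a 1.1-fold higher number from compound 2 to compound 3 (0.03 log units; within the scatter), and isopropyl in place of propyl on a saturated chain carbon gave a 1.4-fold lower number from compound 1 to compound 2 (0.14 log units; within the scatter). Each of these stays within the scatter, so among these three compounds, reshaping the alkyl group has not moved the read-out in this assay. Among the compounds with values here, none of the measured compounds carries a ring at this place, however, so cyclohexyl goes beyond what the data cover, and the range is kept wide. No step beyond the scatter is expected, in either direction. The expected change is a 1.2-fold lower number from compound 3 to compound 4 (0.08 log units; within the scatter), an estimate that stays within the scatter. For compound 4 the estimated value is 7000 nM, with an expected range from 3000 nM to 15000 nM.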

Compound 4, half-maximal inhibitory concentration: 10000 nM
The estimate for compound 4 lay 1.4-fold (0.15 log units) below the measured number; low and high end bracket the measured number.
By their numbers in this assay, from the lowest: compounds 2, 3, 4 and 1 (each within the scatter of the next).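

In this assay, a ring at this place, on an aromatic carbon of the six-membered aromatic ring, proves no different from the open-chain groups: cyclohexyl in place of tert-butyl gives a 1.2-fold higher number from compound 3 to compound 4 (0.08 log units; within the scatter), cyclohexyl in place of isobutyl gives a 1.3-fold higher number from compound 2 to compound 4 (0.11 log units; within the scatter), and cyclohexyl in place of butyl gives a 1.1-fold lower number from compound 1 to compound 4 (0.03 log units; within the scatter). All three steps lie within the scatter, so the insensitivity seen among the linear and branched alkyl groups now also covers a six-membered non-aromatic ring of carbon only, and none of the four compounds goes against it. No measurement at hand accounts for this lack of response.

On these data alone, all four compounds carry a group of only carbon and hydrogen at this place, so it remains open whether an amine, a carboxylic acid or a phenyl ring there would leave the number in the same range. The shared core is also the same throughout, which leaves open what a change elsewhere on it, rather than on this group, would do to inhibition.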